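Trimming a Side-Chain Branch on the Ring Carbon

A few compounds are considered here, and "the series" means these few. Any claim that something is new, unique, unknown or untested is made for them only; others in the source may bear on it.

Going by the values given here, compound 1 `C#CC(=O)N1C(C(CC)CCCC)SC[C@@H]1C(=O)OCC` gives 1600 nM in a functional assay on MV cells (Homo sapiens) for inhibition, read by sulforhodamine B assay (on this read-out lower numbers stand for stronger inhibition and higher numbers for weaker inhibition), the highest of the two numbers measured so far. Among the compounds with values here, compound 2 `C#CC(=O)N1C(CCCC)SC[C@@H]1C(=O)OCC` gives 400 nM in this assay, and the single recorded step, a 4.0-fold lower number from compound 1 to compound 2 (0.60 log units; beyond the scatter), went with butyl in place of 1-ethylpentyl. Compound 3 `C#CC(=O)N1C(CCCCC)SC[C@@H]1C(=O)OCC` differs from compound 1 by hydrogen in place of ethyl on a saturated chain carbon bound to a saturated chain carbon and a saturated ring carbon, a similar trimming of the branch. Guided by that step, compound 3 is expected to give a lower number of comparable size, a 3.2-fold lower number from compound 1 to compound 3 (0.51 log units; beyond the scatter). Compound 3 is therefore estimated at 500 nM, within 200 nM to 1300 nM.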

Compound 3, half-maximal inhibitory concentration: 2000 nM
Compound 3: the middle estimate sits 4.0-fold (0.60 log units) below what was measured; the whole stated range lies below it.
By their numbers in this assay, from the lowest: compound 2; then compounds 1 and 3 (each within the scatter of the next).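

In this assay the ethyl branch alone turns out to matter little at this position, with a 1.3-fold higher number from compound 1 to compound 3 (0.10 log units; within the scatter) on going from 1-ethylpentyl to pentyl. The larger difference lies in chain length: methyl in place of hydrogen, four bonds along the chain from a saturated ring carbon, goes with a 5.0-fold higher number from compound 2 to compound 3 (0.70 log units; beyond the scatter), so the lower number of compound 2 cannot be credited to losing the branch alone. No measurement here explains this dependence on the chain. On these data alone, whether a shorter propyl chain, or an amine at the chain end, would lower the number further remains open.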